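The source may hold more compounds than are shown below. What is called first, only, known or untested is meant among the compounds shown, and "the series" means these compounds.

Compound 2 `CCCN(Cc1ccccc1)c1ccc(C(=O)N2CCc3ccc(OS(N)(=O)=O)cc3C2)cc1` holds the higher of the two numbers in an assay on HEK293 cells for inhibition of Steryl-sulfatase (Homo sapiens), tested at 1 uM (on this read-out higher numbers stand for a stronger effect at the one concentration tested and lower numbers for a weaker effect), where compound 2 gives 94.3%; compound 1 `CCN(Cc1ccccc1)c1ccc(C(=O)N2CCc3ccc(OS(N)(=O)=O)cc3C2)cc1` gives 83.6%. Compound 3 `CN(C)CCCN(Cc1ccccc1)c1ccc(C(=O)N2CCc3ccc(OS(N)(=O)=O)cc3C2)cc1` carries dimethylamino in place of hydrogen on a saturated chain carbon, three bonds along the chain from a nitrogen on an aromatic ring. Among the measured compounds shown here, the only measured step touching this region, a number 10.7 percentage points higher from compound 1 to compound 2 (beyond the scatter), grew the chain by one carbon. That step offers no direct reading on adding dimethylamino, and compound 2 leaves little room for a further gain, so a step of a number 6.3 percentage points lower from compound 2 to compound 3 (within the scatter) is expected, within the scatter or a small loss. Compound 3 is estimated at 88%, in the range 70% to 98%.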

Compound 3, a percentage reported as inhibition, at one concentration (the size of the read-out at that concentration, not a potency): 61.6%
Compound 3: middle estimate off by 26.4 percentage points, on the high side; measured number outside the range, below it.
By their numbers in this assay, from the lowest: compound 3; then compound 1; then compound 2.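

In this assay, the chain position is not open to every extension: replacing propyl with 3-(dimethylamino)propyl gives a number 32.7 percentage points lower from compound 2 to compound 3 (beyond the scatter), and replacing ethyl with 2-(dimethylamino)ethyl would not describe this pair, whose listed change gives a number 22 percentage points lower from compound 1 to compound 3 (beyond the scatter). The gain from ethyl to propyl therefore does not carry over to a chain ending in dimethylamino, and compound 3 sits lowest of the three. No available evidence bears on the origin of this loss.

Open, as far as these compounds go, is whether the loss follows the terminal amine itself or any end group on this chain. A plain butyl chain, a 3-methoxypropyl chain or a chain ending in a carboxylic acid would separate these readings.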